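From Compound 1 to Compound 4: One Methyl Leaves

The compounds below may be only part of what the source reports. "The series", "measured", "known", "first", "only" and "open" are said of these compounds alone.

In a functional assay on thoracic aorta (Rattus norvegicus, strain Wistar), with a stated time of 15 min (a higher number here means that more compound is needed for the effect, a lower number that less compound is needed), compound 1 (`COc1ccc(F)cc1C(C)NC(=O)N(C)S(=O)(=O)c1ccc(Cl)cc1`) gives 12600 nM. Compound 2 (`CCOc1ccc(F)cc1C(C)NC(=O)N(C)S(=O)(=O)c1ccc(Cl)cc1`) gives 24500 nM, and compound 3 (`COc1ccc(Br)cc1C(C)NC(=O)N(C)S(=O)(=O)c1ccc(Cl)cc1`) gives 19100 nM. Compound 1 is therefore not separated from either neighbour, as all three values lie within the usual scatter of one another.

Compound 4 (`COc1ccc(F)cc1C(C)NC(=O)NS(=O)(=O)c1ccc(Cl)cc1`) has not yet been measured. It carries hydrogen in place of methyl on an amide-type nitrogen, whose other neighbours are the carbonyl carbon and the sulfonyl sulfur (hydrogen in place of methyl on an amide-type nitrogen).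

Two measured steps offer indirect guidance. With methyl in place of hydrogen on a saturated chain carbon bound to an oxygen on an aromatic ring, the series shows a 1.9-fold higher number from compound 1 to compound 2 (0.29 log units; within the scatter). With bromo in place of fluoro on an aromatic carbon, it shows a 1.5-fold higher number from compound 1 to compound 3 (0.18 log units; within the scatter). Within the data shown here, neither step touches the amide-type nitrogen, so the data contain no direct precedent for this change, and its direction remains open. Among the measured compounds shown here, the two steps show only that single small changes elsewhere stayed within the scatter.

The expected step is therefore no larger than the scatter, at a 1.1-fold higher number from compound 1 to compound 4 (0.05 log units; within the scatter). Given the missing precedent, the range is kept wide. Compound 4 is estimated at 14000 nM, with an expected range from 4500 nM to 45000 nM.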

Compound 4, half-maximal effective concentration: > 300000 nM
Compound 4: only a limit was reported; the forecaster's own chance of this, stated with the estimate: 15%; middle value at least 21-fold (1.33 log units) from the limit.
By their numbers in this assay, from the lowest: compounds 1, 3 and 2 (each within the scatter of the next). At a limit, above all of these: compound 4.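

In this assay, hydrogen in place of methyl on the amide-type nitrogen, whose other neighbours are the carbonyl carbon and the sulfonyl sulfur, gives an at least 23-fold higher number from compound 1 to compound 4 (1.37 log units; beyond the scatter). The reading for compound 4 is a limit and not a number: the limit of > 300000 nM in this assay, at which 1 of the 4 values shown sits. Of the steps shown, this is the only one beyond the scatter, since the two changes elsewhere in the molecule stayed within it, so this nitrogen is the one position here at which the exchange of a single group separates two compounds, and only the minimum size of that separation is known.

The compounds shown leave open whether this nitrogen needs a methyl specifically or would accept another group, such as an ethyl or a longer chain, with a number close to that of compound 1. They also leave open whether the same exchange of methyl for hydrogen would have a step of similar size on the cores of compound 2 and compound 3, and they give no cause for the step.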